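The compounds below may be only part of what the source reports. "The series", "measured", "known", "first", "only" and "open" are said of these compounds alone.

Measured so far:
compound 1, `CN(C[C@H]1Cc2c(cccc2N2CCN(Cc3ccccn3)CC2)CN1)[C@H]1CCCc2cccnc21`: > 30000 nM
compound 2, `CCCN(C[C@H]1Cc2c(cccc2N2CCNCC2)CN1)[C@H]1CCCc2cccnc21`: > 30000 nM

In a functional assay on CCRF-CEM cells for agonist activity at C-X-C chemokine receptor type 4 (Homo sapiens), read by calcium flux, with a stated time of 25 min (on this read-out higher numbers stand for an effect only at larger amounts of compound and lower numbers for an effect already at smaller amounts), compound 1 gives > 30000 nM; this is a limit of the assay and not a number. Compound 2 gives > 30000 nM in this assay, and this too is a limit rather than a measured number. Both measured values therefore stand at the same place, namely (the limit of > 30000 nM in this assay, at which 2 of the 2 values shown sit), so compound 2 cannot be ranked against compound 1 beyond saying that neither showed an effect within the tested amounts.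

Compound 3, `c1cnc2c(c1)CCC[C@@H]2N(CC1CC1)C[C@H]1Cc2c(cccc2N2CCNCC2)CN1`, has not yet been tested in this assay. It differs from compound 2 in one place: cyclopropyl in place of ethyl on a saturated chain carbon bound to an amine nitrogen. Among the compounds with values here, no step between two measured compounds is available, so the effect of such a change cannot be read from a measured step here. Because both measured values sit at the limit of > 30000 nM in this assay, at which 2 of the 2 values shown sit, the step of a number no higher from compound 2 to compound 3 (the limit leaves the size open) is expected to be none beyond the scatter, with the assay most likely again reporting only a limit. Compound 3 is estimated to give about 30000 nM in this assay, with a range from 8000 nM to 100000 nM.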

Compound 3, half-maximal effective concentration: > 30000 nM
Compound 3: only a limit was reported (the forecaster's own chance of this, stated with the estimate: 85%); the middle value sits exactly at the limit.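

The results for compound 2 and compound 3 are both limits and not numbers, so no step between them can be read, and the effect of cyclopropyl in place of ethyl stays unknown: the limit of > 30000 nM in this assay, at which 3 of the 3 values shown sit.

The compounds shown leave open which change, if any, would give a readable number in this assay.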